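The source may report more compounds than this note shows. Statements on the series, on what has been measured and on what is new or still open speak of the compounds shown alone.

Working notes on the series in a functional assay on MOLT-4 cells (Homo sapiens) for antiproliferative activity, read by MTT assay, with a stated time of 3 days; on this read-out lower numbers stand for stronger inhibition and higher numbers for weaker inhibition. Compound 1 (`CCCCCCCCC#Cc1cn(C/C=C\CN2C(=O)c3ccccc3C2=O)c(=O)[nH]c1=O`) gives 36000 nM, compound 2 (`O=C1c2ccccc2C(=O)N1C/C=C\Cn1cc(C#Cc2ccc(Br)cc2)c(=O)[nH]c1=O`) gives 89000 nM and compound 3 (`CCCCC#Cc1cn(C/C=C\CN2C(=O)c3ccccc3C2=O)c(=O)[nH]c1=O`) gives 41000 nM. Compound 3 is level with compound 1 within the scatter (a 1.1-fold higher number from compound 1 to compound 3 (0.06 log units; within the scatter)) and lies clear of compound 2 (a 2.2-fold lower number from compound 2 to compound 3 (0.34 log units; beyond the scatter)). Compound 4 (`O=C1c2ccccc2C(=O)N1C/C=C\Cn1cc(C#CCCc2ccccc2)c(=O)[nH]c1=O`) carries one change: phenyl in place of ethyl on a saturated chain carbon, two bonds along the chain from a triple-bonded carbon. Two kinds of step bear on it. The shift between butyl-bearing and hydrogen-ended chains in compound 1 and compound 3 was small, while the aryl end of compound 2 gave a modest rise (a 2.5-fold higher number from compound 1 to compound 2 (0.39 log units; beyond the scatter)). Compound 4 keeps a saturated stretch before its ring, so only a slight upward drift is expected in this assay, with nothing beyond the scatter. The estimated change is a 1.2-fold higher number from compound 3 to compound 4 (0.09 log units; within the scatter). Compound 4 is expected at 50000 nM, within an estimated range of 25000 nM to 100000 nM.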

Compound 4, half-maximal inhibitory concentration: 146000 nM
The estimate for compound 4 lay 2.9-fold (0.47 log units) below the measured number; measured number outside the range, above it.
By their numbers in this assay, from the lowest: compounds 1 and 3 (each within the scatter of the next); then compounds 2 and 4 (each within the scatter of the next).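

In this assay, phenyl in place of ethyl on a saturated chain carbon, two bonds along the chain from a triple-bonded carbon, gives a real loss (a 3.6-fold higher number from compound 3 to compound 4 (0.55 log units; beyond the scatter)), so the saturated stretch does not keep a ring-ended chain level with the open-chain compounds. The step from the octyl-bearing compound is of similar size (a 4.1-fold higher number from compound 1 to compound 4 (0.61 log units; beyond the scatter)), while the phenethyl and 4-bromophenyl compounds stay level (a 1.6-fold higher number from compound 2 to compound 4 (0.21 log units; within the scatter)), which places both ring-bearing compounds apart from compound 1 and compound 3. No evidence at hand accounts for this result. From the compounds shown here alone, whether an amine or a hydroxyl on that phenyl, or a cyclohexyl in its place, would bring the number back towards compound 3 stays open.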